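Cyano for bromo on the trifluoromethyl core: expected effect

The compounds below may be only part of what the source reports. "The series", "measured", "known", "first", "only" and "open" are said of these compounds alone.

Compound 1 `O=C1/C(=C/c2cccnc2)CN(S(=O)(=O)c2ccc(Br)cc2)C/C1=C\c1ccccc1F` gives 8700 nM in a functional assay on HepG2 cells (Homo sapiens) for cytotoxicity, read by MTT assay, with a stated time of 24 h; on this read-out lower numbers stand for stronger inhibition and higher numbers for weaker inhibition. Compound 2 `N#Cc1ccc(S(=O)(=O)N2C/C(=C\c3cccnc3)C(=O)/C(=C/c3ccccc3F)C2)cc1` differs from compound 1 by cyano in place of bromo on an aromatic carbon and in this assay compound 2 gives 6600 nM; the step is a 1.3-fold lower number from compound 1 to compound 2 (0.12 log units; within the scatter). Compound 3 `O=C1/C(=C/c2cccnc2)CN(S(=O)(=O)c2ccc(Br)cc2)C/C1=C\c1ccccc1C(F)(F)F` differs from compound 1 by trifluoromethyl in place of fluoro on an aromatic carbon and in this assay compound 3 gives 2730 nM, with the step of a 3.2-fold lower number from compound 1 to compound 3 (0.50 log units; beyond the scatter); compound 3 holds the lowest of the three numbers. Compound 4 `N#Cc1ccc(S(=O)(=O)N2C/C(=C\c3cccnc3)C(=O)/C(=C/c3ccccc3C(F)(F)F)C2)cc1` is not yet measured. It differs from compound 3 by cyano in place of bromo on an aromatic carbon, the same change as from compound 1 to compound 2, only made on the core of compound 3. The step from compound 3 to compound 4 is expected to be a 1.3-fold lower number from compound 3 to compound 4 (0.11 log units; within the scatter), essentially flat, because a 1.3-fold lower number from compound 1 to compound 2 (0.12 log units; within the scatter) stayed within the scatter; one earlier instance is a thin basis. Compound 4 is therefore estimated at 2100 nM in this assay, expected between 900 nM and 5000 nM.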

Compound 4, half-maximal inhibitory concentration: 5060 nM
For compound 4 the middle estimate is 2.4-fold (0.38 log units) below the measured one, and the stated range ends below it.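

In this assay the new reading of cyano in place of bromo is a 1.9-fold higher number from compound 3 to compound 4 (0.27 log units; within the scatter), and it does not separate from the earlier step on the core of compound 1: the same change on two cores in this assay, a 1.3-fold lower number (0.12 log units; within the scatter) from compound 1 to compound 2 and a 1.9-fold higher number (0.27 log units; within the scatter) from compound 3 to compound 4, 2.4-fold (0.39 log units) apart, within the scatter of two such steps.
Trifluoromethyl in place of fluoro, now read on the core of compound 2 as a 1.3-fold lower number from compound 2 to compound 4 (0.12 log units; within the scatter), likewise does not separate from its earlier step: the same change on two cores in this assay, a 3.2-fold lower number (0.50 log units; beyond the scatter) from compound 1 to compound 3 and a 1.3-fold lower number (0.12 log units; within the scatter) from compound 2 to compound 4, 2.4-fold (0.39 log units) apart, within the scatter of two such steps.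
Each change has only two instances, so this shows no difference between these cores, but it does not show that either step holds on any other core in the series.

The compounds shown leave open how an amine or a carboxylic acid on the same aromatic carbon would read. From the compounds shown here alone, whether a methoxy group in place of trifluoromethyl would follow the same steps also stays open.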